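A Chlorine-Bearing Ring Replaces a Fluorine-Bearing One

A few compounds are considered here, and "the series" means these few. Any claim that something is new, unique, unknown or untested is made for them only; others in the source may bear on it.

Going by the values given here, in a functional assay on COLO 205 cells (Homo sapiens) for inhibition, read by sulforhodamine B assay (a lower number here means a stronger inhibitor of growth, a higher number a weaker inhibitor of growth), compound 3 `Fc1ccc(-c2ccc(-c3ccc(-c4nc5ccccc5[nH]4)cc3)cc2)cc1` gives 100000 nM, the highest number of the three measured so far, while compound 1 `Cc1ccc2[nH]c(-c3ccc(-c4ccc(-c5ccc(N(C)C)cc5)cc4)cc3)nc2c1` gives 9210 nM. Compound 4 `Clc1cccc(-c2ccc(-c3ccc(-c4nc5ccccc5[nH]4)cc3)cc2)c1` carries 3-chlorophenyl in place of 4-fluorophenyl on an aromatic carbon. One measured step brings in the same 3-chlorophenyl group, replacing 4-(dimethylamino)phenyl: a 3.3-fold lower number from compound 1 to compound 2 (0.52 log units; beyond the scatter), a modest change. That pair also carries a methyl group on the core, which compound 3 lacks, so it is only a loose guide. Still, compound 2 `Cc1ccc2[nH]c(-c3ccc(-c4ccc(-c5cccc(Cl)c5)cc4)cc3)nc2c1`, holding the same group, gives 2780 nM, so a lower number is expected. The expected step is a 10-fold lower number from compound 3 to compound 4 (1.00 log units; beyond the scatter). For compound 4 the estimate is 10000 nM, with an expected range of 2500 nM to 60000 nM.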

Compound 4, concentration for 50% growth inhibition: 100000 nM
For compound 4 the middle estimate is 10-fold (1.00 log units) below the measured one; the whole stated range lies below it.
By their numbers in this assay, from the lowest: compound 2; then compound 1; then compounds 3 and 4 (each within the scatter of the next).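

In this assay the change to 3-chlorophenyl from 4-fluorophenyl gives no change at the digits printed from compound 3 to compound 4 (within the scatter) and so, without the methyl group on the core, this ring swap alone does not lower the number. Going by these compounds alone, the single methyl group makes the large difference in this pair, with a 36-fold higher number from compound 2 to compound 4 (1.56 log units; beyond the scatter) when hydrogen replaces it. Nothing measured here explains this dependence on the methyl group.

Still open, on these data alone, is whether the methyl group has a similar effect alongside 4-fluorophenyl. It is also unclear how a carboxylic acid or nitrile on that ring would behave on either core.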